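The source may report more compounds than this note shows. Statements on the series, on what has been measured and on what is new or still open speak of the compounds shown alone.

Measured in a physicochemical assay for lipophilicity, measured as octanol-water partition; a lower number here means a more polar compound, a higher number a more lipophilic compound:
- Compound 1 `CCCC1C(C(=O)OCc2ccccn2)=C(C)NC2=C1C(=O)CCC2`: 2.6
- Compound 2 `CC1=C(C(=O)OCc2ccccn2)C(c2ccc(Br)cc2)C2=C(CCCC2=O)N1`: 2.42
- Compound 3 `CC1=C(C(=O)OCc2cccnc2)C(c2ccccc2[N+](=O)[O-])C2=C(CCCC2=O)N1`: 1.51

Compound 3, at 1.51, is the lowest of the three. Compound 2, at 2.42, and compound 1, at 2.6, both lie higher, beyond the scatter.

Compound 4 `CC1=C(C(=O)OCc2ccccn2)C(c2ccccc2[N+](=O)[O-])C2=C(CCCC2=O)N1` has not yet been measured. It departs from compound 3 in one place: pyridin-2-yl in place of pyridin-3-yl on a saturated chain carbon bound to an oxygen next to a carbonyl group. This puts pyridin-2-yl in place of pyridin-3-yl on a saturated chain carbon bound to an oxygen next to a carbonyl group.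

For the measured compounds named here, no measured step isolates this exchange. The only one available, a number 0.18 log units lower from compound 1 to compound 2 (within the scatter), concerns a saturated ring carbon instead, where 4-bromophenyl replaces propyl, so it offers no direct measure of the exchange. Compound 2 already carries pyridin-2-yl, but it also differs from compound 3 at that ring carbon, so the gap between their values cannot be assigned to the pyridinyl group alone.

With the counted atoms unchanged, only a small shift is expected in this assay, with no clear move beyond the scatter. The expected step is a number 0.14 log units higher from compound 3 to compound 4 (within the scatter).

For compound 4 the estimated value is 1.65, with an expected range of 1.3 to 2.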

Compound 4, partition coefficient: 1.88
Beside the measured number, compound 4's estimate is 0.23 log units below it, and the stated range covers the measured number.
By their numbers in this assay, from the lowest: compound 3; then compound 4; then compounds 2 and 1 (each within the scatter of the next).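

In this assay, pyridin-2-yl in place of pyridin-3-yl on a saturated chain carbon bound to an oxygen next to a carbonyl group gives a number 0.37 log units higher from compound 3 to compound 4 (beyond the scatter), so this place registers an exchange that leaves the counted heavy atoms, donors and acceptors unchanged. With pyridin-2-yl held fixed, the saturated ring carbon also proves responsive: a number 0.18 log units lower from compound 1 to compound 2 (within the scatter) had shown no separation between propyl and 4-bromophenyl, but 2-nitrophenyl in place of 4-bromophenyl gives a number 0.54 log units lower from compound 2 to compound 4 (beyond the scatter), and 2-nitrophenyl in place of propyl gives a number 0.72 log units lower from compound 1 to compound 4 (beyond the scatter). Nothing available accounts for the size or direction of these steps.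

For the compounds shown here, the pyridinyl exchange is seen only with 2-nitrophenyl on the saturated ring carbon, so it remains open whether it would give a similar step with 4-bromophenyl or propyl there. Going by these compounds, it also remains open how pyridin-4-yl or an unsubstituted phenyl on the saturated chain carbon would compare with the two pyridinyl groups in this assay.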